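Swapping aryl groups on a pyrazoline: expected paw edema activity

The source may report more compounds than this note shows. Statements on the series, on what has been measured and on what is new or still open speak of the compounds shown alone.

Of the compounds shown here, three have been tested in a functional assay on the whole organism (strain albino) with Rattus norvegicus as the target, read by paw edema, with stated times of 1 h and 4 h, at a dose of 50 mg/kg by the oral route; a higher number here means a stronger effect of the compound at the dose given, a lower number a weaker effect. Compound 1 `COc1ccc(C2CC(c3ccc(NC(=O)c4cc(Cl)ccc4OC)cc3)=NN2c2ccccc2)cc1` gives 98%. Compound 2 `COc1ccc(Cl)cc1C(=O)Nc1ccc(C2=NN(c3ccccc3)C(c3ccccc3[N+](=O)[O-])C2)cc1` gives 88.4%, which is a number 9.6 percentage points lower from compound 1 to compound 2 (within the scatter); the change is 2-nitrophenyl in place of 4-methoxyphenyl on a saturated ring carbon. Compound 3 `COc1ccc(C2CC(c3ccc(NC(=O)c4cc(Cl)ccc4OC)cc3)=NN2)cc1` gives 89%, which is a number 9 percentage points lower from compound 1 to compound 3 (within the scatter); here the change is hydrogen in place of phenyl on an amine nitrogen in a ring, and this is also how the core of compound 3 differs from the core of compound 1.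

Compound 4 `COc1ccc(Cl)cc1C(=O)Nc1ccc(C2=NNC(c3ccccc3[N+](=O)[O-])C2)cc1` has not yet been measured in this assay. It differs from compound 3 by 2-nitrophenyl in place of 4-methoxyphenyl on a saturated ring carbon. Among the compounds with values here, this is the same kind of change as the one from compound 1 to compound 2, but the surroundings differ: in compound 1 the saturated ring carbon sits next to the ring atom that bears a phenyl group, while in compound 3 that ring atom carries only hydrogen.

The step is expected to be a number 9 percentage points lower from compound 3 to compound 4 (within the scatter), resting on the earlier change, which was a number 9.6 percentage points lower from compound 1 to compound 2 (within the scatter). Compound 4 is thus estimated at 80%, with a range from 68% to 92%.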

Compound 4, a percentage reported as activity, at one dose (the size of the read-out at that dose, not a potency): 90.9%
Compound 4: the middle estimate sits 10.9 percentage points below what was measured, within the range that was stated.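

In this assay, 2-nitrophenyl in place of 4-methoxyphenyl gives a number 1.9 percentage points higher from compound 3 to compound 4 (within the scatter), and beside the earlier step on the core that carries phenyl, the two results cannot be told apart: the same change on two cores in this assay, a number 9.6 percentage points lower (within the scatter) from compound 1 to compound 2 and a number 1.9 percentage points higher (within the scatter) from compound 3 to compound 4, 11.5 percentage points apart, within the scatter of two such steps. Hydrogen in place of phenyl on the ring nitrogen gives a number 2.5 percentage points higher from compound 2 to compound 4 (within the scatter), and this change also looks no different on the two cores: the same change on two cores in this assay, a number 9 percentage points lower (within the scatter) from compound 1 to compound 3 and a number 2.5 percentage points higher (within the scatter) from compound 2 to compound 4, 11.5 percentage points apart, within the scatter of two such steps. This means that neither change can be said to depend on the core, but it does not prove that a change carries over exactly, and with every step inside the scatter, neither change is shown to alter the activity at all.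

The compounds shown leave open whether a carboxylic acid or an amine on the aryl ring at the saturated ring carbon would give a step beyond the scatter. They also leave open what a longer chain on the ring nitrogen would do, and whether the effect of the compounds would be stronger or weaker at any other dose, as each number comes from a single dose.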